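From compound 2 to compound 3: a new end group

A few compounds are considered here, and "the series" means these few. Any claim that something is new, unique, unknown or untested is made for them only; others in the source may bear on it.

In a functional assay on NCI-H460 cells (Homo sapiens) for inhibition, with a stated time of 72 h (on this read-out lower numbers stand for stronger inhibition and higher numbers for weaker inhibition), compound 1 `O=C(/C=C/c1ccc(-c2ccccc2)cc1)NO` gives 5400 nM. Compound 2 `NNC(=O)/C=C/c1ccc(-c2ccccc2)cc1` gives > 20000 nM, which is a limit of the assay and not a number. That leaves compound 2 at the limit of > 20000 nM in this assay, at which 1 of the 2 values shown sits.

For the measured compounds named here, the one measured step is an at least 3.7-fold higher number from compound 1 to compound 2 (0.56 log units; beyond the scatter), with amino in place of hydroxy on an amide-type nitrogen. Compound 3 `CC(=O)SCC(=O)/C=C/c1ccc(-c2ccccc2)cc1` differs from compound 2 by having (acetylsulfanyl)methyl in place of aminoamino on a carbonyl carbon. The measured step also alters the group on that carbonyl carbon, but it involves other groups, so it cannot fix the size of this new change. Compound 2 has only a limit, so any step from it stays loose. With compound 1 at 5400 nM, the shared core can give a measurable number, so a modest move toward a lower number is expected. The estimated step is an at least 1.8-fold lower number from compound 2 to compound 3 (0.25 log units; that floor lies within the scatter). For compound 3 the estimate is 11000 nM, with an expected range of 3000 nM to 20000 nM.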

Compound 3, half-maximal inhibitory concentration: > 20000 nM
Compound 3: a limit, no number; the forecaster's own chance of this, stated with the estimate: 35%; middle value at least 1.8-fold (0.25 log units) from the limit.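

In this assay compound 3 gives > 20000 nM, which is a limit of the assay and not a number. Putting (acetylsulfanyl)methyl in place of hydroxyamino on the carbonyl carbon brings an at least 3.7-fold higher number from compound 1 to compound 3 (0.56 log units; beyond the scatter), so a second replacement for hydroxyamino, with a different make-up from aminoamino, also ends without a measurable number. The step between compound 2 and compound 3 cannot be read, which leaves aminoamino and (acetylsulfanyl)methyl unranked, and among the three end groups shown on the shared core, only the hydroxyamino of compound 1 gives a number, while the other two stop at the same limit: the limit of > 20000 nM in this assay, at which 2 of the 3 values shown sit.

From the compounds shown here alone, how far past that limit compound 2 and compound 3 really lie stays open, so the loss from compound 1 is known only as a floor. Also open, going by these compounds, is whether another group on that carbonyl carbon, such as a hydroxy group giving a carboxylic acid or a sulfanylmethyl group with a free thiol, would bring back a measurable number.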